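Series notes: amine variation on the shared core

This account rests on a few compounds, and the source may have more. Where it says the series, first, only, none or still open, it means among the compounds named here.

compound 1 `COc1cc2nc(NCc3ccccc3)nc(NC3CCCCCC3)c2cc1OC` gives 13% in an in vitro functional assay on B300-19 cells for antagonist activity at C-C chemokine receptor type 4 (Homo sapiens), read by GTPgammaS binding, tested at 1 uM; a higher number here means more inhibition at the concentration tested (going by the name of the read-out), a lower number less inhibition
compound 2 `COc1cc2nc(NCCN3CCCCC3)nc(NC3CCCCCC3)c2cc1OC` gives 1% in this assay
compound 3 `COc1cc2nc(NCCCN3CCCC3=O)nc(NC3CCCCCC3)c2cc1OC` gives 8% in this assay

Compound 3 holds the middle number of the three, but both gaps to it are within the scatter: a number 5 percentage points lower from compound 1 to compound 3 (within the scatter) and a number 7 percentage points higher from compound 2 to compound 3 (within the scatter). For the measured compounds named here, the only step beyond the scatter is a number 12 percentage points lower from compound 1 to compound 2 (beyond the scatter), a modest one. All three values are low at the concentration tested.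

Compound 4 `COc1cc2nc(NCc3cccs3)nc(NC3CCCCCC3)c2cc1OC` is not yet measured. It differs from compound 3 as follows: thiophen-2-yl in place of 2-(2-oxopyrrolidin-1-yl)ethyl on a saturated chain carbon bound to a nitrogen on an aromatic ring.

Going by the values given here, the step that bears most closely on this is the one from compound 1 to compound 3, since compound 1 carries phenyl at the same place and thiophen-2-yl is likewise a five-membered aromatic ring; that step was within the scatter. The step from compound 2 to compound 3 was also within the scatter. Among the compounds with values here, no measured step moves the number far, so in this assay no change beyond the scatter is expected, with a slight lean upward toward the value of compound 1: a number 4 percentage points higher from compound 3 to compound 4 (within the scatter). Compound 4 is therefore estimated at 12%, expected within 2% to 22%.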

Compound 4, a percentage reported as inhibition, at one concentration (the size of the read-out at that concentration, not a potency): 0%
For compound 4 the middle estimate is 12 percentage points above the measured one; measured number below the stated range.
By their numbers in this assay, from the lowest: compounds 4, 2, 3 and 1 (each within the scatter of the next, the first and the last beyond it).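

Thiophen-2-yl in place of phenyl on a saturated chain carbon bound to a nitrogen on an aromatic ring, read in this assay, gives a number 13 percentage points lower from compound 1 to compound 4 (beyond the scatter), so exchanging one aromatic ring for another at this place is not neutral, and an aromatic ring there does not by itself hold the number of compound 1. The other two steps, a number 8 percentage points lower from compound 3 to compound 4 (within the scatter) and a number 1 percentage points lower from compound 2 to compound 4 (within the scatter), leave compound 4 inseparable from compound 2 and compound 3, although those carry no aromatic ring at this place. No measured evidence here explains the step from phenyl to thiophen-2-yl.

As far as these compounds go, whether furan-2-yl, pyridin-2-yl or a 4-methoxyphenyl at this place would stay with compound 1 or with compound 4 remains open. Also open, from the compounds shown here alone, is whether any group at this place on the shared core gives more than low inhibition.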